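Swapping neopentyl for butyl: a clearance estimate

A few compounds are considered here, and "the series" means these few. Any claim that something is new, unique, unknown or untested is made for them only; others in the source may bear on it.

In an ADME assay on liver for metabolic stability, with Liver microsome (Homo sapiens) as the target, read by LC-MS, using microsomes (on this read-out higher numbers stand for fast clearance and lower numbers for slow clearance), compound 1 `Cc1cccc([C@@H](O)C(=O)N2N=CC[C@H]2C(=O)NCc2cc(Cl)ccc2-n2cnnn2)c1` gives < 12 mL.min-1.g-1, which is a limit of the assay and not a number. Going by the values given here, compound 2 `CC(C)(C)C[C@@H](O)C(=O)N1N=CC[C@H]1C(=O)NCc1cc(Cl)ccc1-n1cnnn1` gives 22 mL.min-1.g-1, the only exact number so far. Compound 3 `CCCC[C@@H](O)C(=O)N1N=CC[C@H]1C(=O)NCc1cc(Cl)ccc1-n1cnnn1` differs from compound 2 in one place: propyl in place of tert-butyl on a saturated chain carbon, two bonds along the chain from a carbonyl carbon and an oxygen on a saturated carbon. Put another way, a neopentyl becomes a butyl. Among the compounds with values here, the single measured step that bears on this change, neopentyl in place of 3-methylphenyl, is an at least 1.8-fold higher number from compound 1 to compound 2 (0.26 log units; that floor lies within the scatter). That step replaced a ring with a chain, whereas here one chain replaces another, so it offers only a loose guide to size. No shift beyond the scatter is therefore expected, and the estimated step is a 1.0-fold lower number from compound 2 to compound 3 (0.02 log units; within the scatter). For compound 3 the expected clearance is 21 mL.min-1.g-1, with an estimated range from 12 mL.min-1.g-1 to 40 mL.min-1.g-1.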

Compound 3, intrinsic clearance in microsomes: < 12 mL.min-1.g-1
Compound 3: only a limit was reported; the forecaster's own chance of this, stated with the estimate: 15%; at least 1.7-fold (0.24 log units) between middle value and limit.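

For compound 3, the read-out in this assay is a limit of the assay and not a number. Going from neopentyl to butyl at this position gives an at least 1.8-fold lower number from compound 2 to compound 3 (0.26 log units; that floor lies within the scatter), so this result is the first sign that the shape of a chain here may matter, although the true size of the step remains unknown and its floor does not clear the scatter. The step from compound 1 to compound 3 cannot be read, because both compounds stand at the same limit, which hides any difference between a 3-methylphenyl and a butyl: the limit of < 12 mL.min-1.g-1 in this assay, at which 2 of the 3 values shown sit.

On these data alone, how far below the limit compound 3 truly lies remains open. Also open, as far as these compounds go, is whether a longer chain such as pentyl, or a cyclohexyl ring, at this place would stay at the limit or give a measurable number.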